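The compounds below may be only part of what the source reports. "The series", "measured", "known", "first", "only" and "open" are said of these compounds alone.

Compound 1, `COc1ccc(S(=O)(=O)Oc2ccccc2/C=C(\C#N)C(=O)Nc2nnc(Cc3cccc4ccccc34)s2)cc1`: 98%
Compound 2, `N#C/C(=C\c1ccccc1OS(=O)(=O)c1ccc([N+](=O)[O-])cc1)C(=O)Nc1nnc(Cc2cccc3ccccc23)s1`: 18%
Compound 3, `COc1ccc(S(=O)(=O)Oc2ccccc2/C=C(\C#N)C(=O)Nc2nnc(Cc3ccc(F)cc3)s2)cc1`: 100%

All three were measured in a functional assay on HL-60 cells (Homo sapiens) for inhibition, read by CCK-8 assay, with a stated time of 48 h, tested at 20 uM; on this read-out lower numbers stand for less inhibition of growth and higher numbers for more inhibition of growth at the one concentration tested. Compound 3 differs from compound 1 by 4-fluorophenyl in place of naphthalen-1-yl on a saturated chain carbon bound to an aromatic carbon, and the step of a number 2 percentage points higher from compound 1 to compound 3 (within the scatter). Compound 2 differs from compound 1 by nitro in place of methoxy on an aromatic carbon, and here the step was a number 80 percentage points lower from compound 1 to compound 2 (beyond the scatter).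

Compound 4, `N#C/C(=C\c1ccccc1OS(=O)(=O)c1ccc([N+](=O)[O-])cc1)C(=O)Nc1nnc(Cc2ccc(F)cc2)s1`, has not yet been measured in this assay. It differs from compound 3 by nitro in place of methoxy on an aromatic carbon, the same change made from compound 1 to compound 2, at the same place on the shared core; among these compounds it occurs twice. A step of similar size is expected, a number 80 percentage points lower from compound 3 to compound 4 (beyond the scatter), because the earlier step of a number 80 percentage points lower from compound 1 to compound 2 (beyond the scatter) was large. For compound 4 the estimated value in this assay is 20%, expected to lie between 5% and 45%.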

Compound 4, percent growth inhibition at one concentration: 18%
Estimate against measurement, compound 4: 2 percentage points above, within the range that was stated.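

In this assay, nitro in place of methoxy gave a number 82 percentage points lower from compound 3 to compound 4 (beyond the scatter), which matches the step seen earlier on the core of compound 1: the same change on two cores in this assay, a number 80 percentage points lower (beyond the scatter) from compound 1 to compound 2 and a number 82 percentage points lower (beyond the scatter) from compound 3 to compound 4, 2 percentage points apart, within the scatter of two such steps

The other change, 4-fluorophenyl in place of naphthalen-1-yl, gave no change at the digits printed from compound 2 to compound 4 (within the scatter), and it too agrees across the two cores: the same change on two cores in this assay, a number 2 percentage points higher (within the scatter) from compound 1 to compound 3 and no change at the digits printed (within the scatter) from compound 2 to compound 4, 2 percentage points apart, within the scatter of two such steps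

Within these four compounds, each change therefore carried over from one core to the other, but this rests on a single concentration and two cores, and it does not show that either change would carry over to any other core.

The compounds shown leave open what an amine or a chlorine would give at the place held by methoxy and nitro. Also open, on these data alone, is what a carboxylic acid or a longer chain would give in place of the 4-fluorophenyl.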